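The compounds below may be only part of what the source reports. "The series", "measured", "known", "first", "only" and "open" are said of these compounds alone.

Measured so far in an ADME assay on L929 cells (Mus musculus) for cytotoxicity; on this read-out higher numbers stand for weaker inhibition and lower numbers for stronger inhibition:
compound 1 `CN1CC(OCc2ccc(OCc3ccccc3)cc2)Cn2nc([N+](=O)[O-])cc21` gives > 10 ug/mL
compound 2 `O=[N+]([O-])c1cn2c(n1)[S@+]([O-])C[C@@H](OCc1ccc(OC(F)(F)F)cc1)C2` gives > 10 ug/mL
compound 3 `O=[N+]([O-])c1cn2c(n1)OCC(COc1ccc(-c3ccc(OC(F)(F)F)cc3)nc1)C2` gives > 10 ug/mL

Each of these values is a limit of the assay rather than a number. Compound 2 stands at the limit of > 10 ug/mL in this assay, at which 3 of the 3 values shown sit, so its position is known only as that limit, level with the other two. Compound 4 `O=[N+]([O-])c1cn2c(n1)[S@@+]([O-])C[C@H](OCc1ccc(OC(F)(F)F)cc1)C2` is the mirror image of compound 2: the two compounds have the same atoms and bonds and differ only in configuration as drawn: 2 of 2 stereo elements differ (all stereocentres are inverted: mirror images); a stereocentre at a sulfur is drawn R in compound 2 and S in compound 4; a stereocentre at a saturated ring carbon is drawn S in compound 2 and R in compound 4. Within the data shown here, no step between measured compounds exists to anchor a direction; for a change of configuration alone, the step expected in this assay is none beyond the scatter, a step that the limit leaves unreadable from compound 2 to compound 4. Compound 4 is therefore estimated at 30 ug/mL, with a range from 10 ug/mL to 100 ug/mL, and most likely reported once more only as a limit.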

Compound 4, half-maximal inhibitory concentration: > 10 ug/mL
Compound 4: only a limit was reported; the forecaster's own chance of this, stated with the estimate: 85%; the middle value is on the limit's open side.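

Compound 2 and compound 4, which are mirror images, are each reported only as a limit in this assay, so no step can be read between them. The compounds shown leave open whether configuration matters here, and where any true value lies.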